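The source may report more compounds than this note shows. Statements on the series, on what has been measured and on what is new or still open speak of the compounds shown alone.

Measured so far:
- compound 1, `COC1=CC(=O)c2c(c(COC(=O)c3ccccc3F)cn2C)C1=O`, in a functional assay on V79-379A cells (Cricetulus griseus) for cytotoxicity, read by MTT assay, in the presence of a further agent that is not named here (on this read-out higher numbers stand for weaker inhibition and lower numbers for stronger inhibition), compound 1 gives 40 nM
- compound 2, `COC1=CC(=O)c2c(c(COC(C)=O)c(C)n2C)C1=O`, in this assay compound 2 gives 2500 nM

Compound 2 holds the highest number of the two. Its nearest neighbour in the numbers is compound 1, which sits far below it, well beyond the scatter, so compound 2 is the weaker of the two measured compounds on this read-out. The two structures differ in more than one place, so nothing is drawn from that gap beyond the two values themselves.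

The next compound, compound 3, `COC1=CC(=O)c2c(c(COC(N)=O)c(C)n2C)C1=O`, is compound 2 with one change: amino in place of methyl on a carbonyl carbon. The acetoxymethyl arm of compound 2 becomes a (carbamoyloxy)methyl arm. Among the compounds with values here, no measured pair carries this change, so there is no step of this kind to lean on.

The expected step from compound 2 to compound 3 is a 1.7-fold lower number from compound 2 to compound 3 (0.22 log units; within the scatter), a modest drop in the number, probably near the edge of the scatter rather than clearly beyond it. Compound 3 is estimated at 1500 nM, within a range from 400 nM to 6000 nM.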

Compound 3, half-maximal inhibitory concentration: 300 nM
The estimate for compound 3 lay 5.0-fold (0.70 log units) above the measured number, outside the stated range (below it).
By their numbers in this assay, from the lowest: compound 1; then compound 3; then compound 2.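

In this assay, amino in place of methyl on a carbonyl carbon gives an 8.3-fold lower number from compound 2 to compound 3 (0.92 log units; beyond the scatter). Within the data shown here, this is the first step that changes one place only, so it shows that the number depends on the group at this carbonyl carbon, even with the rest of the structure held fixed. The acetoxymethyl and (carbamoyloxy)methyl arms are therefore not interchangeable on this read-out, although the exchange involves a single heavy atom, and nothing shown here accounts for the size of this step.

Open, going by these compounds, is whether the step follows from the amino group as such or would also appear with methylamino, dimethylamino or methoxy on the same carbonyl carbon, since a single pair gives no trend across such groups. Also open, on these data alone, is whether the same exchange would give a similar step on other versions of the core, as compound 1 differs from compound 2 and from compound 3 in more than one place and so cannot be set on this step.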